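This account rests on a few compounds, and the source may have more. Where it says the series, first, only, none or still open, it means among the compounds named here.

Working notes on the sulfonyl group, read-out a physicochemical assay for solubility, in phosphate buffer, measured as kinetic solubility, at pH 7.4, tested at 250 uM; on this read-out lower numbers stand for lower solubility and higher numbers for higher solubility. Compound 3 `O=C(O)c1ccc(NCCCCCCCC(F)(F)F)c(S(=O)(=O)N2CCOCC2)c1` stands at 244000 nM, within the scatter of compound 1 `CCCCCCNc1ccc(C(=O)O)cc1S(=O)(=O)NC` at 247000 nM. Compound 2 `O=C(O)c1ccc(NCCCCCCCC(F)(F)F)c(S(=O)(=O)N2CCCC2)c1`, at 66000 nM, lies lower than both, beyond the scatter.

The next change leads to compound 4 `O=C(O)c1ccc(NCCCCCCCC(F)(F)F)c(S(=O)(=O)NC2CCOCC2)c1`: (oxan-4-yl)amino in place of morpholin-4-yl on a sulfonyl sulfur. In words, this is (oxan-4-yl)amino in place of morpholin-4-yl on a sulfonyl sulfur.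

Within the data shown here, only one measured step bears on this place: a 3.7-fold higher number from compound 2 to compound 3 (0.57 log units; beyond the scatter), a modest change with morpholin-4-yl in place of pyrrolidin-1-yl on a sulfonyl sulfur. Among the measured compounds shown here, it is a different swap, so it gives a rough scale and no direct precedent. For the measured compounds named here, compound 1 differs from compound 3 in more than one place and provides no clean step.

Compound 3, at 244000 nM, already sits close to the top concentration tested in this assay, so little upward room is expected. Going by the values given here, a small downward move is more likely, no larger than the single measured step and possibly within the scatter. The expected step is a 1.6-fold lower number from compound 3 to compound 4 (0.21 log units; within the scatter).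

For compound 4 the estimated value is 150000 nM, with an expected range from 65000 nM to 250000 nM.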

Compound 4, solubility: 244000 nM
Estimate against measurement, compound 4: 1.6-fold (0.21 log units) below, within the range that was stated.
By their numbers in this assay, from the lowest: compound 2; then compounds 3, 4 and 1 (each within the scatter of the next).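

In this assay, the new step reads no change at the digits printed from compound 3 to compound 4 (within the scatter), so (oxan-4-yl)amino and morpholin-4-yl cannot be told apart on this sulfonyl sulfur, even though the entering group has 1 hydrogen-bond donor, which morpholin-4-yl lacks, and a ring with 1 hetero atom where morpholin-4-yl has 2. Measured against pyrrolidin-1-yl, (oxan-4-yl)amino gives a 3.7-fold higher number from compound 2 to compound 4 (0.57 log units; beyond the scatter), matching a 3.7-fold higher number from compound 2 to compound 3 (0.57 log units; beyond the scatter), which leaves the pyrrolidin-1-yl compound as the one standing apart among these three, with no compound among them going against that. No supporting measurement bears on why these groups fall as they do.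

Still open, as far as these compounds go, is whether the ring oxygen accounts for the step from the pyrrolidin-1-yl compound, which a piperidin-1-yl or cyclohexylamino group on the same sulfur would address. Compound 3 and compound 4 also both lie close to the top concentration tested, and any real difference between them may not show on this read-out.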